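Bromo to fluoro swap in an antiproliferative series

The compounds below may be only part of what the source reports. "The series", "measured", "known", "first", "only" and "open" are said of these compounds alone.

Measured compounds:
compound 1, `CCN1CCN(c2cc(C)c3cc(NC(=O)c4ccccc4F)ccc3n2)CC1`, 38100 nM
compound 2, `CCN1CCN(c2cc(C)c3cc(NC(=O)c4ccccc4Br)ccc3n2)CC1`, 39200 nM
compound 3, `CCN1CCN(c2cc(C)c3cc(NC(=O)c4cccc(Br)c4)ccc3n2)CC1`, 13300 nM

In a functional assay on SK-BR-3 cells (Homo sapiens) for antiproliferative activity, read by MTT assay, with a stated time of 72 h (a lower number here means a stronger inhibitor, a higher number a weaker inhibitor), compound 2 gives 39200 nM and compound 1 gives 38100 nM. The change between them is fluoro in place of bromo on an aromatic carbon, and the step of a 1.0-fold lower number from compound 2 to compound 1 (0.01 log units; within the scatter) is within the scatter. Compound 3 differs from compound 2 by 3-bromophenyl in place of 2-bromophenyl on a carbonyl carbon. Compound 3 gives 13300 nM, with a 2.9-fold lower number from compound 2 to compound 3 (0.47 log units; beyond the scatter).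

Compound 4 `CCN1CCN(c2cc(C)c3cc(NC(=O)c4cccc(F)c4)ccc3n2)CC1` is not yet measured. Its change from compound 3 is fluoro in place of bromo on an aromatic carbon. Going by the values given here, this is the same kind of change as the one from compound 2 to compound 1, but the place differs: meta to a large group here, ortho to a large group there.

For compound 4 the expected step is a 1.1-fold higher number from compound 3 to compound 4 (0.05 log units; within the scatter). This rests on the earlier swap, which gave a 1.0-fold lower number from compound 2 to compound 1 (0.01 log units; within the scatter). Compound 4 is estimated at 15000 nM.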

Compound 4, half-maximal inhibitory concentration: 24900 nM
The estimate for compound 4 lay 1.7-fold (0.22 log units) below the measured number; the measured number falls inside the stated range.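

In this assay, fluoro in place of bromo on an aromatic carbon gave steps that do not differ between the two cores: the same change on two cores in this assay, a 1.0-fold lower number (0.01 log units; within the scatter) from compound 2 to compound 1 and a 1.9-fold higher number (0.27 log units; within the scatter) from compound 3 to compound 4, 1.9-fold (0.28 log units) apart, within the scatter of two such steps. The new step, a 1.9-fold higher number from compound 3 to compound 4 (0.27 log units; within the scatter), stays within the scatter, as do a 1.6-fold lower number from compound 2 to compound 4 (0.20 log units; within the scatter) and a 1.5-fold lower number from compound 1 to compound 4 (0.18 log units; within the scatter), and none of these pairs can be put in order. Going by these compounds alone, two pairs show only that the swap carried over here, not that it would carry to any further core or that it is without effect in general.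

Open, on these data alone, is whether a chloro, methoxy, nitrile or amine group on this aromatic ring would give a step beyond the scatter.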